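Shortening the amine: the step from compound 2 to compound 3

The source may report more compounds than this note shows. Statements on the series, on what has been measured and on what is new or still open speak of the compounds shown alone.

Compound 1 `C=CCc1ccc(O)c(-c2cc(CC=C)cc(CN(C)C(C)C)c2O)c1` and compound 2 `C=CCc1ccc(O)c(-c2cc(CC=C)cc(CN(CC(C)C)CC(C)C)c2O)c1` share one core and differ only in the amine on the chain carbon. In an assay on isolated protein for inhibition of Maltase-glucoamylase (Homo sapiens), with stated times of 15 min and 10 min, tested at 64 uM (on this read-out higher numbers stand for more inhibition at the one concentration tested (going by the name of the read-out) and lower numbers for less inhibition), compound 1 gives 3.4% and compound 2 gives 3.8%; the step of a number 0.4 percentage points higher from compound 1 to compound 2 (within the scatter) leaves compound 2 level with compound 1, within the scatter. Compound 3 `C=CCc1ccc(O)c(-c2cc(CC=C)cc(CN(CCC)CCC)c2O)c1` changes that same place: dipropylamino in place of diisobutylamino on a saturated chain carbon bound to an aromatic carbon. Within the data shown here, the single measured step bears on this, as it too exchanges amine substituents, and it was small. No shift beyond the scatter is therefore expected in this assay, and the step of a number 0.3 percentage points lower from compound 2 to compound 3 (within the scatter) is expected to be flat. Compound 3 is estimated at 3.5%, in the range -4% to 12%.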

Compound 3, a percentage reported as inhibition, at one concentration (the size of the read-out at that concentration, not a potency): 6.3%
The estimate for compound 3 lay 2.8 percentage points below the measured number; the measured number falls inside the stated range.
By their numbers in this assay, from the lowest: compounds 1, 2 and 3 (each within the scatter of the next).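

In this assay, this place now carries three different dialkylamino groups, and the new steps, a number 2.5 percentage points higher from compound 2 to compound 3 (within the scatter) and a number 2.9 percentage points higher from compound 1 to compound 3 (within the scatter), both stay within the scatter. Dipropylamino therefore reads level with both diisobutylamino and isopropyl(methyl)amino, so exchanging these amines on the saturated chain carbon bound to an aromatic carbon has shown no clear shift. No supporting evidence is available to interpret these numbers further. On these data alone, whether an amine bearing a carboxylic acid, or a longer chain such as dibutylamino, would move the number beyond the scatter remains open.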